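Replacing isopropyl with 4-fluorophenyl: antiproliferative notes

The source may report more compounds than this note shows. Statements on the series, on what has been measured and on what is new or still open speak of the compounds shown alone.

compound 1 `COc1cccc(N2C(=O)COc3ccc(-c4cnc(Cl)c(NS(=O)(=O)c5ccc(F)cc5)c4)cc32)c1`: 32700 nM
compound 2 `CC(C)N1C(=O)COc2ccc(-c3cccc(NS(=O)(=O)c4ccc(F)cc4)c3)cc21`: 29400 nM

In a functional assay on A549 cells (Homo sapiens) for antiproliferative activity, read by MTT assay, with a stated time of 72 h (a lower number here means a stronger inhibitor, a higher number a weaker inhibitor), compound 2 stands within the scatter of compound 1. Compound 3 `O=C1COc2ccc(-c3cccc(NS(=O)(=O)c4ccc(F)cc4)c3)cc2N1c1ccc(F)cc1` carries 4-fluorophenyl in place of isopropyl on an amide-type nitrogen in a ring. Among the compounds with values here, no measured pair isolates this change. Compound 1 also bears a substituted phenyl on that nitrogen and gives 32700 nM, though it differs elsewhere too. On that basis, no step beyond the scatter is expected in this assay. The expected size is a 1.1-fold lower number from compound 2 to compound 3 (0.05 log units; within the scatter). For compound 3 the estimated value is 26000 nM, with an expected range of 9000 nM to 60000 nM.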

Compound 3, half-maximal inhibitory concentration: > 40000 nM
Compound 3: a limit, no number; the forecaster's own chance of this, stated with the estimate: 20%; middle value at least 1.5-fold (0.18 log units) from the limit.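

In this assay, within the data shown here, this is the first pair that isolates the group on the amide-type nitrogen in a ring, and 4-fluorophenyl in place of isopropyl brings no stronger reading: the step is an at least 1.3-fold higher number from compound 2 to compound 3 (0.13 log units; that floor lies within the scatter). That step rests on a floor alone, so its true size stays unread. Compound 3 gives a limit, not a number: the limit of > 40000 nM in this assay, at which 1 of the 3 values shown sits.

From the compounds shown here alone, whether this change carries a real loss remains open. Also open, going by these compounds, is how a longer chain ending in an amine or a carboxylic acid on that nitrogen would read on the shared core.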